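The compounds below may be only part of what the source reports. "The series", "measured", "known", "first", "only" and "open" are said of these compounds alone.

Working notes on the series. Compound 1 `CCCC[C@]1(CC)CS(=O)(=O)c2ccc(OC)cc2[C@@H](c2ccccc2)[C@H]1O` gives in an assay on cells for inhibition of ileal sodium/bile acid cotransporter (Homo sapiens) (on this read-out higher numbers stand for weaker inhibition and lower numbers for stronger inhibition), a value of 55 nM. Compound 2 `CCCC[C@]1(CC)CS(=O)(=O)c2ccc(N(C)C)cc2[C@@H](c2ccccc2)[C@H]1O` differs from compound 1 by dimethylamino in place of methoxy on an aromatic carbon, and in this assay compound 2 gives 5 nM; the step is an 11-fold lower number from compound 1 to compound 2 (1.04 log units; beyond the scatter). Compound 3 `CCCCC1(CCCC)CS(=O)(=O)c2cc(OC)ccc2[C@@H](c2ccccc2)[C@H]1O` has a core whose difference from the core of compound 1 is not broken down here, and in this assay compound 3 gives 190 nM. Compound 4 `CCCCC1(CCCC)CS(=O)(=O)c2cc(N(C)C)ccc2[C@@H](c2ccccc2)[C@H]1O` is not yet measured; it differs from compound 3 by dimethylamino in place of methoxy on an aromatic carbon, the same change as that from compound 1 to compound 2, since the place is described in the same words for both pairs. The step expected in this assay is a 9.5-fold lower number from compound 3 to compound 4 (0.98 log units; beyond the scatter), resting on the step seen in an 11-fold lower number from compound 1 to compound 2 (1.04 log units; beyond the scatter) and on compound 3 starting at 190 nM. Compound 4 is estimated at 20 nM, in a range from 8 nM to 60 nM.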

Compound 4, half-maximal inhibitory concentration: 120 nM
Beside the measured number, compound 4's estimate is 6.0-fold (0.78 log units) below it; the measured number lies above the stated range.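

In this assay, dimethylamino in place of methoxy on an aromatic carbon gives a 1.6-fold lower number from compound 3 to compound 4 (0.20 log units; within the scatter), so on this core the change moves the number by no more than the scatter. The change therefore does not carry over in size from one core to the other: the same change on two cores in this assay, an 11-fold lower number (1.04 log units; beyond the scatter) from compound 1 to compound 2 and a 1.6-fold lower number (0.20 log units; within the scatter) from compound 3 to compound 4, 6.9-fold (0.84 log units) apart, beyond the scatter of two such steps Two pairs show only that the size of this step depends on the core; they do not show which of the differences between the two cores is responsible, or how the step behaves on any third core.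

Still open, from the compounds shown here alone, is how the step would run on a core that differs from that of compound 1 in one place only. Also open, going by these compounds, is whether a primary amine or diethylamino on the same aromatic carbon would follow compound 2 or compound 4.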